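The compounds below may be only part of what the source reports. "The series", "measured", "known", "first", "only" and "open" are said of these compounds alone.

Measured so far in a functional assay on HEK293 cells with D(4) dopamine receptor (Homo sapiens) as the target, read by FLIPR; on this read-out higher numbers stand for larger maximal responses and lower numbers for smaller maximal responses:
compound 1, `Cc1ccc(O)c(/C(CCN2CCN(c3ccccn3)CC2)=N/O)c1`: 73%
compound 2, `N#Cc1cccnc1N1CCN(CC/C(=N\O)c2ccccc2)CC1`: 64%
compound 3, `N#Cc1cccnc1N1CCN(CC/C(=N/O)c2ccccc2)CC1`: 49%

Compound 2 stands second highest of the three; compound 1 lies within the scatter of it, compound 3 lies beyond the scatter below it. Among the compounds with values here, the only measured step, a number 15 percentage points lower from compound 2 to compound 3 (beyond the scatter), rests on the fact that compounds 2 and 3 differ only in the configuration as drawn and concerns the drawn configuration alone.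

Compound 4 is `O/N=C(\CCN1CCN(c2nccs2)CC1)c1ccccc1`; against compound 2 the change is 1,3-thiazol-2-yl in place of 3-cyanopyridin-2-yl on an amine nitrogen in a ring. Within the data shown here, no measured step touches the group on the amine nitrogen in a ring, so the configuration step gives no guide here; compound 1, which differs from compound 2 in more than one place, sits within the scatter of compound 2. The expected step of a number 1 percentage points higher from compound 2 to compound 4 (within the scatter) is therefore none beyond the scatter. Compound 4 is estimated at 65%, between 45% and 85%.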

Compound 4, largest response reached (reported as efficacy), in percent of the reference or control that the assay uses: 44%
Beside the measured number, compound 4's estimate is 21 percentage points above it; the whole stated range lies above it.
By their numbers in this assay, from the lowest: compounds 4 and 3 (each within the scatter of the next); then compounds 2 and 1 (each within the scatter of the next).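

The group on the amine nitrogen in a ring is not neutral for the maximal response in this assay: 1,3-thiazol-2-yl in place of 3-cyanopyridin-2-yl gives a number 20 percentage points lower from compound 2 to compound 4 (beyond the scatter) on the shared core. This position therefore joins the drawn double-bond configuration as a second place where a single change goes beyond the scatter. Nothing at hand bears on why this change lowers the response.

Open, as far as these compounds go, is whether the nitrile, the ring size or the sulfur carries the step, which a phenyl or pyrimidin-2-yl group on that nitrogen would help to separate. Also open, from the compounds shown here alone, is whether the configuration step holds with 1,3-thiazol-2-yl in place.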